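Swapping the Amidine for an Acetyl Group

This account rests on a few compounds, and the source may have more. Where it says the series, first, only, none or still open, it means among the compounds named here.

Compound 1 `CCOc1ccc(Br)cc1-c1cc(Nc2ccc(C(N)=O)cc2)nc(N)n1` gives 750 nM in an assay on Sf9 cells for inhibition of 1-acyl-sn-glycerol-3-phosphate acyltransferase beta (Homo sapiens); on this read-out higher numbers stand for weaker inhibition and lower numbers for stronger inhibition.
Compound 2 `CCOc1ccc(Br)cc1-c1cc(Nc2ccc(C(=N)N)cc2)nc(N)n1` gives > 5000 nM in this assay.

Compound 2 stands at the edge of what is known: in this assay compound 2 returns only a limit, > 5000 nM, and not a number. Within the data shown here, the single measured step, an at least 6.6-fold higher number from compound 1 to compound 2 (0.82 log units; beyond the scatter), exchanges the carboxamide of compound 1 for an amidine and ends at that limit (the limit of > 5000 nM in this assay, at which 1 of the 2 values shown sits). Compound 3 `CCOc1ccc(Br)cc1-c1cc(Nc2ccc(C(C)=O)cc2)nc(N)n1` now removes the amidine again: a group of 3 heavy atoms (2 carbon, 1 oxygen; no ring) in place of a group of 3 heavy atoms (1 carbon, 2 nitrogen; no ring), on an aromatic carbon. Because the step of an at least 6.6-fold higher number from compound 1 to compound 2 (0.82 log units; beyond the scatter) showed that putting the amidine in place weakened inhibition beyond the scatter, taking it out is expected to move the number back down, toward the region of compound 1, though the acetyl is not the carboxamide and the gap may not close fully. Compound 3 is therefore estimated at 1500 nM in this assay, between 500 nM and 5000 nM. This estimate means an expected step of an at least 3.3-fold lower number from compound 2 to compound 3 (0.52 log units; beyond the scatter).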

Compound 3, half-maximal inhibitory concentration: 34 nM
Compound 3: middle estimate off by 44-fold (1.64 log units), on the high side, and the stated range ends above it.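

The earlier compounds shown here showed only that this position, para to a large group, could lose inhibition; methyl in place of amino on the carbonyl carbon now gives a 22-fold lower number from compound 1 to compound 3 (1.34 log units; beyond the scatter), so the carboxamide was no ceiling here. Acetyl in place of the amidine gives an at least 140-fold lower number from compound 2 to compound 3 (2.16 log units; beyond the scatter) in this assay, and the gain therefore goes well beyond what the amidine had cost. Compound 2 gives only a limit, so that step has no exact size: the limit of > 5000 nM in this assay, at which 1 of the 3 values shown sits.

The compounds shown leave open whether a longer chain on the carbonyl, such as propanoyl, would hold this level of inhibition, or whether a methyl ester or a carboxylic acid would. They also do not tell why the acetyl outperforms the carboxamide.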